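Compound 1 to compound 3: swapping one ring substituent

The compounds below may be only part of what the source reports. "The series", "measured", "known", "first", "only" and "open" are said of these compounds alone.

Measured so far in a physicochemical assay for solubility, read by LC-MS, in phosphate buffer, with a stated time of 24 h, at pH 7.4; a higher number here means a more soluble compound, a lower number a less soluble compound 
- compound 1 `Cc1nccn1-c1cnc(NCc2c(F)ccc3c2CCO3)c2cn[nH]c(=O)c12` gives 7000 nM 
- compound 2 `Cc1ncccc1-c1cnc(NCc2c(F)ccc3c2CCO3)c2ncc(=O)[nH]c12` gives 29000 nM 

Compound 1 holds the lower of the two numbers, and its gap to compound 2 lies beyond the usual scatter. Compound 3 `O=C1CCCN1c1cnc(NCc2c(F)ccc3c2CCO3)c2cn[nH]c(=O)c12` keeps the core of compound 1 and carries 2-oxopyrrolidin-1-yl in place of 2-methyl-1H-imidazol-1-yl on an aromatic carbon. Within the data shown here, no measured step isolates this change, so the range stays wide. No step beyond the scatter is expected in this assay in either direction. The estimated step of a 1.2-fold lower number from compound 1 to compound 3 (0.07 log units; within the scatter) is accordingly small. The estimate for compound 3 is 6000 nM (expected range 1500 nM to 25000 nM).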

Compound 3, solubility: < 2000 nM
Compound 3 was reported as a limit; the forecaster's own chance of this, stated with the estimate: 3%; middle value at least 3.0-fold (0.47 log units) from the limit.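

Compound 3 gives < 2000 nM in this assay, which is a limit of the assay and not a number. Even so, this aromatic carbon is not a silent position: 2-oxopyrrolidin-1-yl in place of 2-methyl-1H-imidazol-1-yl comes with an at least 3.5-fold lower number from compound 1 to compound 3 (0.54 log units; beyond the scatter). The full size of that step stays open at one end: the limit of < 2000 nM in this assay, at which 1 of the 3 values shown sits.

The compounds shown do not separate loss of the aromatic ring from entry of the carbonyl. Also open, going by these compounds, is how an amine such as morpholine, or a carboxylic acid, would read at this position on the core of compound 1.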